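Cyclopropylmethyl purine amines: inhibition at one dose

A few compounds are considered here, and "the series" means these few. Any claim that something is new, unique, unknown or untested is made for them only; others in the source may bear on it.

Measured compounds:
- compound 1, `CC(C)N(C)c1ncnc2c1ncn2CC1CC1`, in a functional assay on the whole organism for inhibition, with Rattus norvegicus as the target, at a dose of 25 mg/kg by the intraperitoneal route (a higher number here means more inhibition at the dose given (going by the name of the read-out), a lower number less inhibition), compound 1 gives 32%
- compound 2, `CC(C)(C)Nc1ncnc2c1ncn2CC1CC1`, in this assay compound 2 gives 0%

Among the compounds with values here, compound 2 stands lowest of the two numbers; its nearest neighbour is compound 1, and the one measured step, a number 32 percentage points lower from compound 1 to compound 2 (beyond the scatter), runs from isopropyl(methyl)amino to (tert-butyl)amino on the aromatic carbon and is beyond the scatter.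

Compound 3, `c1nc(NCC2CC2)c2ncn(CC3CC3)c2n1`, is not yet measured. It differs from compound 2 by cyclopropylmethyl in place of tert-butyl on a nitrogen on an aromatic ring. Within the data shown here, no measured step changes the group on this nitrogen in the same way, so the only guide is that the one change made at this amine, from compound 1 to compound 2, moved the read-out by a large amount. A change of similar kind is therefore expected to be capable of a sizeable shift, and since compound 2 shows no inhibition, any shift can only be upward. The step expected from compound 2 to compound 3 is a number 15 percentage points higher from compound 2 to compound 3 (beyond the scatter), though it may also remain within the scatter. Compound 3 is estimated at 15% in this assay, with a range from 0% to 40%.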

Compound 3, a percentage reported as inhibition, in the whole organism at one dose (the size of the read-out at that dose, not a potency): 28%
Compound 3: middle estimate off by 13 percentage points, on the low side; the measured number falls inside the stated range.
By their numbers in this assay, from the lowest: compound 2; then compounds 3 and 1 (each within the scatter of the next).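

Working notes: in this assay, a number 28 percentage points higher from compound 2 to compound 3 (beyond the scatter), with cyclopropylmethyl in place of tert-butyl on a nitrogen on an aromatic ring and the heavy-atom count of the group unchanged, so the two groups are not interchangeable at this position. a number 4 percentage points lower from compound 1 to compound 3 (within the scatter), which lies within the scatter, so (cyclopropylmethyl)amino and isopropyl(methyl)amino cannot be told apart here and the amine hydrogen kept in compound 3 is compatible with inhibition at this dose, leaving the empty reading of compound 2 at 0% tied, among these three compounds, to (tert-butyl)amino rather than to an amine hydrogen as such. Nothing available on these compounds accounts for the gap between tert-butyl and cyclopropylmethyl.

Still open, going by these compounds, is whether the three-membered ring matters at this nitrogen, or whether an isobutyl or n-butyl group, or a cyclobutyl ring, would read like cyclopropylmethyl or like tert-butyl. Also open, on these data alone, is how far the inhibition depends on the cyclopropylmethyl group on the shared core, which a benzyl group or a longer chain there would test, and each reading, at a single dose, gives no potency.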